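The source may report more compounds than this note shows. Statements on the series, on what has been measured and on what is new or still open speak of the compounds shown alone.

The two compounds already measured share a core that carries a trifluoromethylphenyl group and a sulfur-bearing heteroaryl ring. Compound 1, `Cn1nc(-c2nnc(SCc3ccc(C(F)(F)F)cc3)o2)cc1-c1ccc(C(F)(F)F)cc1`, carries a 4-trifluoromethylbenzyl group on that sulfur, and in a functional assay on Ehrlich cells (Mus musculus) for cytotoxicity, read by MTT assay, with a stated time of 24 h (a higher number here means a weaker inhibitor, a lower number a stronger inhibitor), compound 1 gives 20500 nM. Compound 2, `Cn1nc(-c2ccc(C(F)(F)F)cc2)cc1-c1nnc(S)o1`, leaves the sulfur bare as a thiol, and in this assay compound 2 gives 75300 nM, the higher of the two numbers; the gap between compound 2 and compound 1 lies beyond the usual scatter, so compound 2 is the weaker of the two measured compounds in this assay.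

Compound 3, `Cn1nc(-c2ccc(C(F)(F)F)cc2)cc1-c1nnc(SCc2cccc([N+](=O)[O-])c2)o1`, is obtained from compound 2 by the change (3-nitrobenzyl in place of hydrogen on a sulfur). Among the compounds with values here, no measured pair shows exactly this change, but compound 1 shows what a benzyl-type group on this sulfur can do alongside the bare thiol of compound 2. On that basis the step of a 3.0-fold lower number from compound 2 to compound 3 (0.48 log units; beyond the scatter) is expected to be a decrease, moving compound 3 toward the value of compound 1 rather than beyond the scatter in the other direction. Compound 3 is therefore estimated to give 25000 nM in this assay, with a range from 8000 nM to 80000 nM.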

Compound 3, half-maximal inhibitory concentration: > 100000 nM
Compound 3: no number, only a limit; the forecaster's own chance of this, stated with the estimate: 10%; at least 4.0-fold (0.60 log units) between middle value and limit.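

Within the data shown here, this is the first pair that differs in one place, and it gives a direct reading of the sulfur position: in this assay, putting 3-nitrobenzyl in place of hydrogen on the sulfur does not give a lower number, and the result is an at least 1.3-fold higher number from compound 2 to compound 3 (0.12 log units; that floor lies within the scatter). On these data alone, compound 3 gives > 100000 nM, which is a limit of the assay and not a number, so the true size of the step is unknown and its printed floor does not establish a real rise over the thiol. Compound 3 is the only compound shown that stands at this limit: the limit of > 100000 nM in this assay, at which 1 of the 3 values shown sits.

Compound 1 differs from compound 3 in more than one place, so the compounds shown leave open whether the 4-trifluoromethylbenzyl group of compound 1 would lower the number on the core of compound 3, and whether the nitro group or the benzyl frame decides the outcome. They also leave open what a plain benzyl group, a 4-nitrobenzyl group, a short alkyl chain or a chain ending in a carboxylic acid would give on this sulfur.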